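This account rests on a few compounds, and the source may have more. Where it says the series, first, only, none or still open, it means among the compounds named here.

Compound 1 `Cc1ccccc1C[C@H]1C(=O)OC[C@@H]1Cc1ccccc1`: 57000 nM
Compound 2 `O=C1OC[C@H](Cc2ccccc2)[C@H]1Cc1cccc(OC(F)(F)F)c1`: 34000 nM

In a functional assay on HL-60 cells (Homo sapiens) for cytotoxicity, read by WST assay, with a stated time of 48 h (a lower number here means that less compound is needed, a higher number that more compound is needed for the effect), compound 2 gives 34000 nM, and compound 1 lies within the scatter of it. Compound 3 `Cc1cccc(C[C@H]2C(=O)OC[C@@H]2Cc2ccccc2)c1` follows from compound 2 by methyl in place of trifluoromethoxy on an aromatic carbon, with methyl in place of trifluoromethoxy on an aromatic carbon. Going by the values given here, no measured pair differs in one place, so the expectation rests on the two values alone. Compound 1, which also carries a methyl, gives 57000 nM. No change beyond the scatter is expected in this assay. The expected size is a 1.3-fold higher number from compound 2 to compound 3 (0.12 log units; within the scatter). For compound 3 the estimate is 45000 nM, with an expected range of 20000 nM to 90000 nM.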

Compound 3, half-maximal effective concentration: 53000 nM
Estimate against measurement, compound 3: 1.2-fold (0.07 log units) below, and the stated range covers the measured number.
By their numbers in this assay, from the lowest: compounds 2, 3 and 1 (each within the scatter of the next).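

Within this assay replacing the trifluoromethoxy with a methyl, meta to a large group, gives a 1.6-fold higher number from compound 2 to compound 3 (0.19 log units; within the scatter) and so does not separate the two groups here. The methyl position also goes untold: 3-methylphenyl in place of 2-methylphenyl gives a 1.1-fold lower number from compound 1 to compound 3 (0.03 log units; within the scatter) and leaves the two compounds within the scatter. Nothing measured bears on why these numbers stay together. Going by these compounds, what an amine or a carboxylic acid at this aromatic carbon would give stays open. Also open, on these data alone, is whether any change to the shared core would separate compounds in this assay.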